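Aryl swap on a series of N-benzyl piperidinyl ether limits

This account rests on a few compounds, and the source may have more. Where it says the series, first, only, none or still open, it means among the compounds named here.

Measured compounds in an assay on isolated protein for activation of cGMP-dependent protein kinase 1 (Homo sapiens), read by ADP-Glo, with stated times of 30 min and 2 h; on this read-out lower numbers stand for an effect already at smaller amounts and higher numbers for an effect only at larger amounts of compound:
Compound 1 `Cc1cc(C(=O)O)ccc1CN1CCC[C@H](O[C@H](CO)c2ccccc2)[C@@H]1c1ccccc1` gives > 200000 nM, which is a limit of the assay, not a number.
Compound 2 `OC[C@@H](O[C@H]1CCCN(Cc2ncc[nH]2)[C@H]1c1ccccc1)c1cc(Cl)cc(Cl)c1` gives > 200000 nM, again a limit of the assay.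
Compound 3 `OC[C@@H](O[C@H]1CCCN(Cc2nc3ccccc3[nH]2)[C@H]1c1ccccc1)c1cc(Cl)cc(Cl)c1` gives > 200000 nM, again a limit of the assay.

Compound 1 therefore stands nowhere distinguishable on the numbers shown: its value is only a limit, and the other two values shown are limits as well, as summed up in the limit of > 200000 nM in this assay, at which 3 of the 3 values shown sit. Among the measured compounds shown here, the one step between measured compounds that differ in a single place, from compound 2 to compound 3, is a step that the two limits leave unreadable from compound 2 to compound 3, so it gives no readable size either.

Compound 4 `Cc1cc(C(=O)O)ccc1CN1CCC[C@H](O[C@H](CO)c2ccnc(Cl)c2)[C@@H]1c1ccccc1` differs from compound 1 by 2-chloropyridin-4-yl in place of phenyl on a saturated chain carbon bound to an oxygen on a saturated carbon and a saturated chain carbon. For the measured compounds named here, no measured step touches this position or this kind of exchange; the single measured step concerns a different place on the shared core and is itself unreadable. The expectation for compound 4 can therefore rest only on the fact that every value shown sits at the limit described in the limit of > 200000 nM in this assay, at which 3 of the 3 values shown sit, which gives no handle on direction or size.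

On this basis compound 4 is expected to give 200000 nM in this assay, with a range from 50000 nM to 1000000 nM. The step from compound 1 to compound 4 is thus estimated as a number no higher from compound 1 to compound 4 (the limit leaves the size open), that is, no change that could be read against a limit, with a high chance that the assay again reports only a limit.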

Compound 4, half-maximal effective concentration: > 200000 nM
Compound 4: a limit, no number (the forecaster's own chance of this, stated with the estimate: 80%); the middle value lies on the limit itself.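

Compound 1 and compound 4 both stand only as limits in this assay, so the exchange of phenyl for 2-chloropyridin-4-yl gives no readable step, and the same holds for all values shown: the limit of > 200000 nM in this assay, at which 4 of the 4 values shown sit.

The compounds shown leave open whether any exchange on the shared core brings a measurable effect, since none of these values is a number.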